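Pyridin-3-yl for trifluoromethylphenyl: expected cytotoxicity of compound 4

A few compounds are considered here, and "the series" means these few. Any claim that something is new, unique, unknown or untested is made for them only; others in the source may bear on it.

The measured compounds:
Compound 1, `NC(=S)N1CCCc2c(OCCCCCOc3cccc4ccccc34)cccc21`: in an ADME assay on Huh-7 cells (Homo sapiens) for cytotoxicity (on this read-out higher numbers stand for lower toxicity in this test and lower numbers for higher toxicity in this test), compound 1 gives > 50000 nM, which is a limit of the assay and not a number.
Compound 2, `O=C(NC(=S)N1CCc2cc(OCc3ccccc3)ccc21)c1ccccc1`: in this assay compound 2 gives 45200 nM.
Compound 3, `O=C(NC(=S)N1CCc2c(OCCCCCOc3ccc(Cl)cc3)cccc21)c1ccc(C(F)(F)F)cc1`: in this assay compound 3 gives 32700 nM.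

Of the two values that are numbers, compound 3 holds the lower one. Its nearest neighbour is compound 2, and the gap between the two lies within the scatter, so neither can be called more or less toxic than the other. The value of compound 1 is only a limit, (the limit of > 50000 nM in this assay, at which 1 of the 3 values shown sits). For the measured compounds named here, no two measured compounds differ in a single place, so no measured step is available to guide the next change.

Compound 4, `O=C(NC(=S)N1CCc2c(OCCCCCOc3ccc(Cl)cc3)cccc21)c1cccnc1`, has not yet been measured in this assay. It differs from compound 3 in one place: pyridin-3-yl in place of 4-(trifluoromethyl)phenyl on a carbonyl carbon. Both groups sit on the same carbonyl carbon of an otherwise unchanged molecule.

Going by the values given here, with no measured step to lean on, the step expected for compound 4 in this assay is small, no larger than the scatter, and if anything toward a higher number. Compound 4 is therefore expected to give about 42000 nM, in a range from 20000 nM to 80000 nM. The expected step is a 1.3-fold higher number from compound 3 to compound 4 (0.11 log units; within the scatter).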

Compound 4, half-maximal cytotoxic concentration: 11100 nM
Compound 4: middle estimate off by 3.8-fold (0.58 log units), on the high side, and the stated range ends above it.
By their numbers in this assay, from the lowest: compound 4; then compounds 3 and 2 (each within the scatter of the next). At a limit, above all of these: compound 1.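

In this assay, the carbonyl position proves able to shift the read-out on its own: with the rest of the molecule unchanged, pyridin-3-yl in place of 4-(trifluoromethyl)phenyl gives a modest step beyond the scatter, toward higher toxicity in this test (a 2.9-fold lower number from compound 3 to compound 4 (0.47 log units; beyond the scatter)). The earlier compounds shown here could not show this, as they differ from one another in more than one place and so left the contribution of this group unseparated from that of the rest of each structure. Nothing measured here gives a cause for this step, and the only supporting note concerns an assay limit that has no bearing on it.

The change swaps a carbon-only ring bearing trifluoromethyl for a ring with one hetero atom, so this single step cannot tell whether the ring nitrogen, the loss of trifluoromethyl or both account for it. Going by these compounds, a plain phenyl or a 4-chlorophenyl on the same carbonyl carbon, or pyridin-4-yl, would begin to separate these, and whether the step holds on a different core or with a shorter chain remains open.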